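A few compounds are considered here, and "the series" means these few. Any claim that something is new, unique, unknown or untested is made for them only; others in the source may bear on it.

Compound 1 `Cn1cnc2c(Sc3ccccc3)ncnc21`: 0%
Compound 2 `Cn1c(-c2ccccc2)nc2c(Sc3ccccc3)ncnc21`: 42%

Of the compounds shown here, two have been measured in an assay on isolated protein for inhibition of RAC-alpha serine/threonine-protein kinase (Homo sapiens), tested at 30 uM; a lower number here means less inhibition, a higher number more inhibition at the concentration tested (going by the name of the read-out). Compound 2 stands highest of the two numbers; its nearest neighbour is compound 1, and the step of a number 42 percentage points higher from compound 1 to compound 2 (beyond the scatter) came with phenyl in place of hydrogen on an aromatic carbon, a change beyond the scatter.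

Compound 3 `CSc1ccc(-c2nc3c(Sc4ccccc4)ncnc3n2C)cc1` is the next compound of the series. It differs from compound 2 by methylsulfanyl in place of hydrogen on an aromatic carbon; cut one bond further out, the same difference reads phenyl to 4-(methylsulfanyl)phenyl.

Among the compounds with values here, the only measured step, from compound 1 to compound 2, concerns the arrival of the phenyl itself, not a substituent on it, so no measured step bears directly on the change to compound 3. The data give no ground for a step beyond the scatter in either direction in this assay. Compound 3 is therefore expected to give about 45%, with a range from 20% to 70%. The step this estimate means, a number 3 percentage points higher from compound 2 to compound 3 (within the scatter), is expected to lie within the usual scatter.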

Compound 3, a percentage reported as inhibition, at one concentration (the size of the read-out at that concentration, not a potency): 5%
Compound 3: middle estimate off by 40 percentage points, on the high side, outside the stated range (below it).
By their numbers in this assay, from the lowest: compounds 1 and 3 (each within the scatter of the next); then compound 2.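

In this assay, this place on the phenyl ring proves far from indifferent: methylsulfanyl in place of hydrogen, on an aromatic carbon para to a large group, gives a number 37 percentage points lower from compound 2 to compound 3 (beyond the scatter), so the inhibition that arrived with the phenyl does not carry over to this substituted ring. Measured against the core of compound 1, the whole 4-(methylsulfanyl)phenyl group gives a number 5 percentage points higher from compound 1 to compound 3 (within the scatter), which means that this read-out does not separate compound 1 and compound 3, and that an aryl group at this carbon does not by itself secure inhibition. Nothing available bears on why this substituent has such an effect.

The compounds shown leave open whether the loss belongs to methylsulfanyl alone or to any group at this place on the ring, a question that a fluorine, a methoxy, an amine or a carboxylic acid there could help to settle. They also leave open whether methylsulfanyl would give the same result at another carbon of the phenyl ring.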